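Methoxy to hydrogen on the pendant phenyl: carrying a step over

The compounds below may be only part of what the source reports. "The series", "measured", "known", "first", "only" and "open" are said of these compounds alone.

Compound 3, `COc1ccc(-c2[nH]c3ccc(OC)cc3c2C=C(C#N)C#N)cc1`, carries a methoxy on the pendant phenyl and two nitriles on the exocyclic double bond. In a functional assay on NCI-H226 cells (Homo sapiens) for inhibition, read by sulforhodamine B assay, with a stated time of 48 h (on this read-out higher numbers stand for weaker inhibition of growth and lower numbers for stronger inhibition of growth), compound 3 gives 1500 nM. Compound 1, `COc1ccc2[nH]c(-c3ccccc3)c(C=C(C#N)C#N)c2c1`, differs from it by hydrogen in place of methoxy on an aromatic carbon; in this assay compound 1 gives 3500 nM, so that a 2.3-fold higher number from compound 3 to compound 1 (0.37 log units; beyond the scatter). Compound 2, `COc1ccc(-c2[nH]c3ccc(OC)cc3c2/C=C(\C#N)S(=O)(=O)c2ccccc2)cc1`, keeps the methoxy on the pendant phenyl but has a phenylsulfonyl group in place of one nitrile; in this assay compound 2 gives 3700 nM. How the core of compound 2 differs from the core of compound 3 is not broken down here; their two values show compound 2 with the higher number, beyond the scatter, while compound 2 and compound 1 lie within the scatter of each other.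

Compound 4, `COc1ccc2[nH]c(-c3ccccc3)c(/C=C(\C#N)S(=O)(=O)c3ccccc3)c2c1`, has not yet been measured in this assay. It differs from compound 2 by hydrogen in place of methoxy on an aromatic carbon. Within the data shown here, this is the same change as the one from compound 3 to compound 1, at the same place on the pendant phenyl. The expectation is that the step carries over, so that compound 4 is estimated to give 8500 nM in this assay, plausibly between 4000 nM and 18000 nM. The expected step is a 2.3-fold higher number from compound 2 to compound 4 (0.36 log units; beyond the scatter). Among the measured compounds shown here, that rests on compound 3 and compound 1, where a 2.3-fold higher number from compound 3 to compound 1 (0.37 log units; beyond the scatter), the only occurrence of this change among the measured compounds.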

Compound 4, concentration for 50% growth inhibition: 9400 nM
Beside the measured number, compound 4's estimate is 1.1-fold (0.04 log units) below it; the range from low to high includes it.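

In this assay, taking the methoxy off the pendant phenyl on the core of compound 2 gives a 2.5-fold higher number from compound 2 to compound 4 (0.40 log units; beyond the scatter), and this step can be set against the earlier one on the core of compound 3: the same change on two cores in this assay, a 2.3-fold higher number (0.37 log units; beyond the scatter) from compound 3 to compound 1 and a 2.5-fold higher number (0.40 log units; beyond the scatter) from compound 2 to compound 4, 1.1-fold (0.04 log units) apart, within the scatter of two such steps On these two cores, then, 4-methoxyphenyl to phenyl moves the number in the same direction and by sizes that cannot be told apart, so a step read on one of them served as a usable guide to the other. Among these compounds, this does not show that the step holds on any further core, since it rests on only two matched pairs in a single cell assay, and the two cores differ only in having a nitrile or a phenylsulfonyl group on the exocyclic double bond; nor does it say why the number moves.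

The compounds shown leave open whether a different group in the same place on the pendant phenyl, such as an amine, a carboxylic acid or a longer alkoxy chain, would move the number in the same direction as methoxy does. They also leave open whether the step would keep its size with a carboxylic ester or an amide in place of the nitrile or phenylsulfonyl group on the double bond.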